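The source may report more compounds than this note shows. Statements on the series, on what has been measured and on what is new or still open speak of the compounds shown alone.

Within the data shown here, compound 2 `COc1ccc(Cn2c(CCc3ccccc3)nnc2[C@H](NC(=O)Cc2ccccn2)c2c[nH]c3ccccc23)cc1` gives 6 nM in a functional assay on CHO cells for antagonist activity at growth hormone secretagogue receptor type 1 (Homo sapiens) (on this read-out lower numbers stand for stronger inhibition and higher numbers for weaker inhibition), the lowest of the two numbers measured so far; compound 1 `CCc1ccc(Cn2c(CCc3ccccc3)nnc2[C@H](NC(=O)Cc2ccccn2)c2c[nH]c3ccccc23)cc1` gives 124 nM. Among the measured compounds shown here, the single measured step, a 21-fold lower number from compound 1 to compound 2 (1.32 log units; beyond the scatter), concerns a different part of the shared core and so does not bear on the change considered here. Compound 3 `COc1ccc(Cn2c(CCc3ccccc3)nnc2[C@H](NC(=O)c2cnccn2)c2c[nH]c3ccccc23)cc1` differs from compound 2 by pyrazin-2-yl in place of (pyridin-2-yl)methyl on a carbonyl carbon. For the measured compounds named here, with no measured step to lean on, compound 3 is expected to show no change beyond the usual scatter, a 1.7-fold higher number from compound 2 to compound 3 (0.22 log units; within the scatter). Compound 3 is therefore estimated at 10 nM, with a range from 2 nM to 50 nM.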

Compound 3, antagonist equilibrium constant: 530 nM
Compound 3: middle estimate off by 53-fold (1.72 log units), on the low side; measured number outside the range, above it.
By their numbers in this assay, from the lowest: compound 2; then compound 1; then compound 3.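

In this assay, the group on the carbonyl carbon proves far from interchangeable: pyrazin-2-yl in place of (pyridin-2-yl)methyl gives an 88-fold higher number from compound 2 to compound 3 (1.95 log units; beyond the scatter), meaning much weaker inhibition. Among these compounds, the earlier pair differed elsewhere, so only this step shows that the position responds strongly to change. No evidence is available on why this happens. The swap alters both the ring and its link to the carbonyl carbon, so the two changes cannot be separated here. Pyridin-2-yl or (pyrazin-2-yl)methyl at this position would change only one of them.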